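Side chain on sulfur: compound 2 to compound 3

A few compounds are considered here, and "the series" means these few. Any claim that something is new, unique, unknown or untested is made for them only; others in the source may bear on it.

Measured in a functional assay on MGC-803 cells (Homo sapiens) for inhibition, read by MTT assay, with a stated time of 72 h (a lower number here means a stronger inhibitor, a higher number a weaker inhibitor), so far:
compound 1 `Cc1cc(Nc2cc(-c3ccccc3)[nH]n2)n2nc(SCCc3ccccc3)nc2n1` gives 5620 nM
compound 2 `Cc1cc(Nc2cc(-c3ccccc3)[nH]n2)n2nc(SCc3ccc(C(F)(F)F)cc3)nc2n1` gives 3520 nM

In this assay compound 2 stands within the scatter of compound 1, so no order holds between them. Compound 3 `CCCSc1nc2nc(C)cc(Nc3cc(-c4ccccc4)[nH]n3)n2n1` carries ethyl in place of 4-(trifluoromethyl)phenyl on a saturated chain carbon bound to a sulfur on the shared core, which also reads as 4-(trifluoromethyl)benzyl to propyl. Going by the values given here, only a 1.6-fold lower number from compound 1 to compound 2 (0.20 log units; within the scatter) bears on this place, and no measured compound lacks the aromatic ring there. The expected change is a 1.4-fold higher number from compound 2 to compound 3 (0.15 log units; within the scatter) with no step beyond the scatter expected. Estimated for compound 3: 5000 nM with an expected range of 1800 nM to 14000 nM.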

Compound 3, half-maximal inhibitory concentration: 12600 nM
Compound 3: middle estimate off by 2.5-fold (0.40 log units), on the low side; the measured number falls inside the stated range.
By their numbers in this assay, from the lowest: compounds 2 and 1 (each within the scatter of the next); then compound 3.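

In this assay, going by these compounds alone, loss of the aromatic ring from the side chain on sulfur gives the first steps at this position beyond the scatter, both modest and both toward a weaker inhibitor (a 3.6-fold higher number from compound 2 to compound 3 (0.55 log units; beyond the scatter)) and (a 2.2-fold higher number from compound 1 to compound 3 (0.35 log units; beyond the scatter)). The propyl chain therefore ranks below both ring-bearing side chains, which themselves stay within the scatter of each other. No measurement on hand explains this difference.

Still open, on these data alone, is whether a longer chain without a ring, such as hexyl, matches the ring-bearing side chains. As far as these compounds go, the effect of an amine or a carboxylic acid at the end of the chain also remains open.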